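Methyl to fluoro on the aryl of compound 2

This account rests on a few compounds, and the source may have more. Where it says the series, first, only, none or still open, it means among the compounds named here.

In a functional assay on DU-145 cells (Homo sapiens) for cytotoxicity, read by MTT assay, with a stated time of 48 h (a lower number here means a stronger inhibitor, a higher number a weaker inhibitor), two compounds of the series have been measured. Compound 1 `CCOC(=O)c1c(-c2c(Cl)c3cc(C)ccc3oc2=O)nn(-c2cccc(C)c2)c1C(=O)OCC` gives 103000 nM. Compound 2 `CCOC(=O)c1c(-c2cc3ccccc3oc2=O)nn(-c2cccc(C)c2)c1C(=O)OCC` gives 47000 nM, the lower of the two numbers; the gap between the two is beyond the usual scatter, but the two compounds differ in more than one place, so no single step can be read from them.

Compound 3 `CCOC(=O)c1c(-c2cc3ccccc3oc2=O)nn(-c2cccc(F)c2)c1C(=O)OCC` has not been measured. It differs from compound 2 by fluoro in place of methyl on an aromatic carbon, or, cut one bond further out, 3-methylphenyl to 3-fluorophenyl. No step of this kind has been measured in the series, so nothing shown bears directly on its size. The change is small as counted, and both measured compounds sit in the same weak region. The step of a 1.1-fold higher number from compound 2 to compound 3 (0.03 log units; within the scatter) is therefore expected to stay within the scatter, with no direction favoured. For compound 3 the estimate is 50000 nM, with a range from 20000 nM to 120000 nM.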

Compound 3, half-maximal inhibitory concentration: 32000 nM
For compound 3 the middle estimate is 1.6-fold (0.19 log units) above the measured one, and the stated range covers the measured number.
By their numbers in this assay, from the lowest: compounds 3 and 2 (each within the scatter of the next); then compound 1.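

In this assay, within the data shown here, the exchange of methyl for fluoro on the aromatic carbon meta to a large group gives a 1.5-fold lower number from compound 2 to compound 3 (0.17 log units; within the scatter), the first step that can be read at a single place. At this position, on the present numbers, 3-methylphenyl and 3-fluorophenyl cannot be told apart, so this one-atom exchange does not move the number beyond the usual scatter, and the step gives no direction for further work on this aryl. No measurement at hand accounts for the size of this step.

As far as these compounds go, whether this position responds at all remains open, since an amine, a carboxylic acid or a longer chain in place of fluoro could show a step that this exchange does not, and the same question holds for a methoxy group or a plain hydrogen there. From the compounds shown here alone, the step from compound 1 to compound 2 cannot be read, as the chloro and methyl groups that set compound 1 apart stay joined in one comparison, and the contribution of each to the value in this assay is still unknown.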